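Quinolin-3-yl in place of 1H-pyrazol-4-yl in compound 2

The compounds below may be only part of what the source reports. "The series", "measured", "known", "first", "only" and "open" are said of these compounds alone.

Going by the values given here, in an ADME assay on microsomes from liver (Homo sapiens) for metabolic stability (a higher number here means faster removal of the compound, a lower number slower removal), compound 2 `Cc1nc(N)nc2c1cc(-c1cn[nH]c1)c(=O)n2[C@H]1CC[C@@H](OCO)CC1` gives 23.4 mL.min-1.g-1, the lower of the two numbers known, while compound 1 `COc1ccc(-c2cc3c(C)nc(N)nc3n([C@H]3CC[C@@H](OCO)CC3)c2=O)cn1` gives 55.7 mL.min-1.g-1. Compound 3 `Cc1nc(N)nc2c1cc(-c1cnc3ccccc3c1)c(=O)n2[C@H]1CC[C@@H](OCO)CC1` carries quinolin-3-yl in place of 1H-pyrazol-4-yl on an aromatic carbon. Among the compounds with values here, the only measured step at this place is a 2.4-fold lower number from compound 1 to compound 2 (0.38 log units; beyond the scatter), a modest change that brings in 1H-pyrazol-4-yl in place of 6-methoxypyridin-3-yl. Read in reverse as the sole guide, that step leads to a modest upward move being expected: a 2.6-fold higher number from compound 2 to compound 3 (0.41 log units; beyond the scatter). For compound 3 the estimated value is 60 mL.min-1.g-1, with an expected range of 30 mL.min-1.g-1 to 120 mL.min-1.g-1.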

Compound 3, intrinsic clearance in microsomes: 105 mL.min-1.g-1
Beside the measured number, compound 3's estimate is 1.8-fold (0.24 log units) below it, within the range that was stated.
By their numbers in this assay, from the lowest: compound 2; then compounds 1 and 3 (each within the scatter of the next).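

At this aromatic carbon, the change from 1H-pyrazol-4-yl to quinolin-3-yl gives a 4.5-fold higher number from compound 2 to compound 3 (0.65 log units; beyond the scatter) in this assay, so 1H-pyrazol-4-yl now stands apart from two different groups rather than one. Those two groups are not separated from each other, with a 1.9-fold higher number from compound 1 to compound 3 (0.28 log units; within the scatter) for the exchange of 6-methoxypyridin-3-yl for quinolin-3-yl. Nothing measured bears on why 1H-pyrazol-4-yl stands apart from them. As far as these compounds go, whether an unsubstituted phenyl, an amine or a carboxylic acid at this carbon would fall with 1H-pyrazol-4-yl or with the other two remains open.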